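Aryl swap series on the shared thione core: toward compound 4

The compounds below may be only part of what the source reports. "The series", "measured", "known", "first", "only" and "open" are said of these compounds alone.

Measured so far:
- compound 1 `CSc1ccc(/C=N/n2c(Cc3ccc(S(C)(=O)=O)cc3)n[nH]c2=S)cc1`: 71.9%
- compound 2 `CS(=O)(=O)c1ccc(Cc2n[nH]c(=S)n2/N=C/c2ccccc2F)cc1`: 28.1%
- compound 3 `CS(=O)(=O)c1ccc(Cc2n[nH]c(=S)n2/N=C/c2ccccc2Cl)cc1`: 76.5%

In a functional assay on HeLa cells (Homo sapiens) for cytotoxicity, read by MTT assay, with a stated time of 48 h, tested at 100 uM (on this read-out lower numbers stand for a weaker effect and higher numbers for a stronger effect at the one concentration tested), compound 3 gives the highest of the three numbers. Its nearest neighbour is compound 1, and the step of a number 4.6 percentage points higher from compound 1 to compound 3 (within the scatter) is within the scatter, so no order between compound 3 and compound 1 can be claimed. Compound 2 lies well apart: the step of a number 48.4 percentage points higher from compound 2 to compound 3 (beyond the scatter) is large.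

Compound 4 `CS(=O)(=O)c1ccc(Cc2n[nH]c(=S)n2/N=C/c2cccs2)cc1` has not been measured. It differs from compound 3 in one place: thiophen-2-yl in place of 2-chlorophenyl on a carbon with a double bond to nitrogen.

Two measured steps alter the same ring: a number 43.8 percentage points lower from compound 1 to compound 2 (beyond the scatter) was large, while a number 4.6 percentage points higher from compound 1 to compound 3 (within the scatter) stayed within the scatter. Changing the group on the carbon with a double bond to nitrogen has thus given both a large drop and no change at all, so the size of the step into compound 4 is uncertain in either direction. A middle position between the two outcomes is the most defensible expectation.

For compound 4 in this assay an estimated value of 55% is expected, with a range from 22% to 82%. Among the measured compounds shown here, the step this estimate implies, a number 21.5 percentage points lower from compound 3 to compound 4 (beyond the scatter), is expected to be a moderate decrease, since the only large step recorded was a loss.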

Compound 4, a percentage reported as activity, at one concentration (the size of the read-out at that concentration, not a potency): 61.1%
Beside the measured number, compound 4's estimate is 6.1 percentage points below it; low and high end bracket the measured number.
By their numbers in this assay, from the lowest: compound 2; then compound 4; then compounds 1 and 3 (each within the scatter of the next).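

In this assay the carbon with a double bond to nitrogen also accepts thiophen-2-yl without a large loss: a number 15.4 percentage points lower from compound 3 to compound 4 (beyond the scatter) and a number 10.8 percentage points lower from compound 1 to compound 4 (beyond the scatter) are both modest, while a number 33 percentage points higher from compound 2 to compound 4 (beyond the scatter) is large. The earlier compounds shown here carried only six-membered aromatic rings of carbon at this position, so compound 4 adds a five-membered aromatic ring with a hetero atom and shows that a modest step, between no change and a large one, is also possible here, with compound 2 still the lowest of the four. No available evidence accounts for the difference between thiophen-2-yl and the phenyl groups at this position.

As far as these compounds go, it remains open whether furan-2-yl or pyridin-2-yl would give a number close to that of compound 4, and whether a carboxylic acid or a dimethylamino group on the phenyl ring would keep the number of compound 3. From the compounds shown here alone, each reading comes from a single concentration, so the order of potency across the series also remains open.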